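This account rests on a few compounds, and the source may have more. Where it says the series, first, only, none or still open, it means among the compounds named here.

Compound 1 `Cc1ccc(NC(=O)[C@H](CC2CCCC2)n2cnc(C(F)(F)F)c2)nc1`: > 120 mL/min/kg, a limit.
Compound 2 `O=C(O)c1ccc(NC(=O)[C@H](CC2CCCC2)n2cnc(C(F)(F)F)c2)nc1`: < 8 mL/min/kg, a limit.
Compound 3 `O=C(O)Cc1ccc(NC(=O)[C@H](CC2CCCC2)n2cnc(C(F)(F)F)c2)nc1`: < 8 mL/min/kg, a limit.

All three come from an in vitro ADME assay on microsomes from liver (Homo sapiens) for metabolic stability (a higher number here means faster removal of the compound, a lower number slower removal), and none is an exact number. Compound 3 stands at the limit of < 8 mL/min/kg in this assay, at which 2 of the 3 values shown sit. Compound 4 `O=C(Nc1ccc(S(=O)(=O)O)cn1)[C@H](CC1CCCC1)n1cnc(C(F)(F)F)c1` carries sulfo in place of carboxymethyl on an aromatic carbon. Within the data shown here, two measured steps bear on this change, both large and beyond the scatter: an at least 15-fold lower number from compound 1 to compound 2 (1.17 log units; beyond the scatter) and an at least 15-fold lower number from compound 1 to compound 3 (1.17 log units; beyond the scatter). The remaining step is a step that the two limits leave unreadable from compound 2 to compound 3, which gives no size. With compound 3 resting on that low limit after an at least 15-fold lower number from compound 1 to compound 3 (1.17 log units; beyond the scatter), no step beyond the scatter is expected in this assay, and a number no lower from compound 3 to compound 4 (the limit leaves the size open) is the expected step. Compound 4 is estimated at 8 mL/min/kg, with an expected range from 4 mL/min/kg to 16 mL/min/kg.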

Compound 4, clearance: < 8 mL/min/kg
Compound 4: a limit, no number; the forecaster's own chance of this, stated with the estimate: 80%; the middle value lies on the limit itself.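

In this assay, sulfo in place of methyl on this aromatic carbon gives an at least 15-fold lower number from compound 1 to compound 4 (1.17 log units; beyond the scatter), so the drop seen with carboxy and carboxymethyl also appears with a group that holds sulfur and oxygen and no carbon. Compound 4 joins compound 2 and compound 3 at one limit: the limit of < 8 mL/min/kg in this assay, at which 3 of the 4 values shown sit. The steps among these three cannot be read, so no order among them can be told.

Going by these compounds, how far each lies under that limit stays open, as does whether an amine or a sulfonamide on this carbon would give the same low reading.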